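The source may hold more compounds than are shown below. What is called first, only, known or untested is meant among the compounds shown, and "the series" means these compounds.

Working notes on the series. Among the compounds with values here, in a functional assay on HCT-15 cells (Homo sapiens) for inhibition (a lower number here means a stronger inhibitor, a higher number a weaker inhibitor), compound 1 `C=CCOC(=O)Nc1nc(=O)n(C2O[C@H](C(=O)O)[C@@H](O)[C@H]2O)cc1F` gives 0.032 ug/mL and compound 2 `C#CCOC(=O)Nc1nc(=O)n(C2O[C@H](C(=O)O)[C@@H](O)[C@H]2O)cc1F` gives 0.04 ug/mL, so compound 2 stands within the scatter of its only measured neighbour. The next compound, compound 3 `O=C(Nc1nc(=O)n(C2O[C@H](C(=O)O)[C@@H](O)[C@H]2O)cc1F)Oc1ccccc1`, differs from compound 2 as follows: phenyl in place of propargyl on an oxygen next to a carbonyl group. In words, this is phenyl in place of propargyl on an oxygen next to a carbonyl group.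

Within the data shown here, only one measured step bears on this change, a 1.3-fold higher number from compound 1 to compound 2 (0.10 log units; within the scatter), with ethynyl in place of vinyl. That step is small, but it involves no aromatic ring, so it is only weak guidance for compound 3. No step beyond the scatter is expected in this assay, and no direction can be supported. The estimated step is a 1.3-fold higher number from compound 2 to compound 3 (0.10 log units; within the scatter). Compound 3 is expected at 0.05 ug/mL, with an estimated range of 0.015 ug/mL to 0.17 ug/mL.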

Compound 3, half-maximal inhibitory concentration: 0.39 ug/mL
Estimate against measurement, compound 3: 7.8-fold (0.89 log units) below; measured number outside the range, above it.
By their numbers in this assay, from the lowest: compounds 1 and 2 (each within the scatter of the next); then compound 3.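

In this assay, the oxygen next to a carbonyl group proves sensitive to what it carries: phenyl in place of propargyl gives a 9.8-fold higher number from compound 2 to compound 3 (0.99 log units; beyond the scatter), and phenyl in place of allyl gives a 12-fold higher number from compound 1 to compound 3 (1.09 log units; beyond the scatter). The earlier exchange between the two unsaturated open chains had stayed within the scatter, so the similar values of compound 1 and compound 2 do not extend to a six-membered aromatic ring of carbon only. Nothing measured in the series accounts for this weakening.

On these data alone, whether the weakening follows the aromatic ring or simply the higher count of heavy atoms stays open: a cyclohexyl group would keep a ring without aromaticity, and a hexyl chain would keep the carbon count without a ring. Also open, as far as these compounds go, is how a benzyl group would read in this assay, with its phenyl held on a carbon rather than directly on the oxygen.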